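Moving a Fluorine in Two Related Compounds

A few compounds are considered here, and "the series" means these few. Any claim that something is new, unique, unknown or untested is made for them only; others in the source may bear on it.

Compound 1 `Oc1cccc(-c2cc(-c3cccc(F)c3)cc(-c3ccccc3O)n2)c1` carries a 3-fluorophenyl group. In a functional assay on DU-145 cells (Homo sapiens) for inhibition (a higher number here means a weaker inhibitor, a lower number a stronger inhibitor), compound 1 gives only a limit, > 50000 nM. Compound 2 `Oc1cccc(-c2cc(-c3ccc(F)cc3)cc(-c3ccccc3O)n2)c1` differs by 4-fluorophenyl in place of 3-fluorophenyl on an aromatic carbon. In this assay compound 2 likewise gives only a limit, > 50000 nM. The step that the two limits leave unreadable from compound 1 to compound 2 cannot be read because of the limit of > 50000 nM in this assay, at which 2 of the 3 values shown sit. Compound 3 `Oc1ccc(-c2cc(-c3cccc(F)c3)cc(-c3ccc(O)cc3)n2)cc1` has a core whose difference from the core of compound 1 is not broken down here, and in this assay compound 3 gives 9290 nM. Compound 4 `Oc1ccc(-c2cc(-c3ccc(F)cc3)cc(-c3ccc(O)cc3)n2)cc1` differs from compound 3 by 4-fluorophenyl in place of 3-fluorophenyl on an aromatic carbon, the same kind of change as from compound 1 to compound 2, although the surroundings differ: here the place is meta to two 4-hydroxyphenyl groups rather than meta to a 2-hydroxyphenyl group and a 3-hydroxyphenyl group. The earlier change left no readable step, and the expected step of a 1.1-fold higher number from compound 3 to compound 4 (0.03 log units; within the scatter) is therefore taken as small. Compound 4 is estimated at 10000 nM.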

Compound 4, half-maximal inhibitory concentration: 6030 nM
The estimate for compound 4 lay 1.7-fold (0.22 log units) above the measured number; the measured number falls inside the stated range.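

In this assay the change from 3-fluorophenyl to 4-fluorophenyl gives a 1.5-fold lower number from compound 3 to compound 4 (0.19 log units; within the scatter) and so, on this core, leaves no difference that can be told from the scatter. This single readable pair supports no general rule for carrying the change between cores. It does not show that the change behaves alike on the core of compound 1, where the step to compound 2 cannot be read because compound 1 and compound 2 each give only a limit: the limit of > 50000 nM in this assay, at which 2 of the 4 values shown sit.

The compounds shown leave open whether an amine or a carboxylic acid in place of the fluorine would move the number beyond the scatter. As far as these compounds go, a plain phenyl group is not among them either, so what the fluorine itself contributes also stays open.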